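Trifluoromethyl for Methyl on the Core of Compound 3

The compounds below may be only part of what the source reports. "The series", "measured", "known", "first", "only" and "open" are said of these compounds alone.

Measured compounds:
Compound 1 `CN(C(=O)NC(=O)c1c(F)cccc1F)c1nc(C(F)(F)F)c(C(=O)N/N=C/c2cccc(C(F)(F)F)c2)s1` gives 25.9 ug/mL in a functional assay on BCG823 cells (Homo sapiens) for inhibition, read by MTT assay, with a stated time of 72 h; a lower number here means a stronger inhibitor, a higher number a weaker inhibitor.
Compound 2 `CN(C(=O)NC(=O)c1ccc(C(F)(F)F)cc1)c1nc(C(F)(F)F)c(C(=O)N/N=C/c2cc(C(F)(F)F)cc(C(F)(F)F)c2)s1` gives 1.77 ug/mL in this assay.
Compound 3 `Cc1nc(N(C)C(=O)NC(=O)c2c(F)cccc2F)sc1C(=O)N/N=C/c1cc(C(F)(F)F)cc(C(F)(F)F)c1` gives 14.1 ug/mL in this assay.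

Compound 3 stands second highest of the three numbers: its value sits within the scatter of compound 1, while compound 2 lies well beyond it, with a much lower number.

Compound 4 `CN(C(=O)NC(=O)c1c(F)cccc1F)c1nc(C(F)(F)F)c(C(=O)N/N=C/c2cc(C(F)(F)F)cc(C(F)(F)F)c2)s1` is the next compound. It differs from compound 3 by trifluoromethyl in place of methyl on an aromatic carbon. Within the data shown here, no measured pair shows this change alone, so its effect is open. Compound 2, the only strong inhibitor here, carries the same trifluoromethyl on the core, which suggests a small step toward a lower number; the expected step of a 1.8-fold lower number from compound 3 to compound 4 (0.25 log units; within the scatter) may well stay within the scatter. Compound 4 is estimated at 8 ug/mL, in the range 2.5 ug/mL to 25 ug/mL.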

Compound 4, half-maximal inhibitory concentration: 5.28 ug/mL
Compound 4: the middle estimate sits 1.5-fold (0.18 log units) above what was measured; measured number inside the range.
By their numbers in this assay, from the lowest: compound 2; then compound 4; then compounds 3 and 1 (each within the scatter of the next).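

In this assay the methyl on the carbon next to the ring nitrogen of the shared core can now be read on its own: trifluoromethyl in its place gives a 2.7-fold lower number from compound 3 to compound 4 (0.43 log units; beyond the scatter) and so this position does respond to the change. The same compound also links two other places, with an extra trifluoromethyl giving a 4.9-fold lower number from compound 1 to compound 4 (0.69 log units; beyond the scatter) and 2,6-difluorophenyl in place of 4-(trifluoromethyl)phenyl on the carbonyl carbon giving a 3.0-fold higher number from compound 2 to compound 4 (0.47 log units; beyond the scatter) as the cost of that swap. Nothing shown explains these steps.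

As far as these compounds go, whether ethyl or chlorine at this position would match trifluoromethyl remains open.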